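A few compounds are considered here, and "the series" means these few. Any claim that something is new, unique, unknown or untested is made for them only; others in the source may bear on it.

Compound 2, `Cc1nc(C)n2c(O)nncc12`, carries a hydroxy on an aromatic carbon of the shared core. In a functional assay for inhibition, with Homo sapiens as the target (a lower number here means a stronger inhibitor, a higher number a weaker inhibitor), compound 2 gives no number, only the limit of the assay, > 48000 nM. Its one comparator, compound 1 `Cc1nc(C)n2c(S)nncc12`, bears a sulfanyl at the same carbon. In this assay compound 1 likewise sits at the limit of the assay, > 48000 nM. Within the data shown here, the single measured step, a step that the two limits leave unreadable from compound 1 to compound 2, therefore cannot be sized, and the whole picture rests on (the limit of > 48000 nM in this assay, at which 2 of the 2 values shown sit).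

Compound 3, `C=CCSc1nncc2c(C)nc(C)n12`, differs from compound 2 by allylsulfanyl in place of hydroxy on an aromatic carbon. Among the measured compounds shown here, no measured step concerns an allylsulfanyl group, so the step from compound 2 to compound 3 in this assay is unsupported by direct evidence; given that both known compounds sit at the limit, compound 3 is expected to show no clear change, an expected step that the limit leaves unreadable from compound 2 to compound 3. For compound 3 the expected value in this assay is 60000 nM, within 20000 nM to 200000 nM.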

Compound 3, half-maximal inhibitory concentration: 59000 nM
The estimate for compound 3 lay 1.0-fold (0.01 log units) above the measured number; low and high end bracket the measured number.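

In this assay compound 3 gives a number, while compound 1 and compound 2 stand only at a limit of the assay, so neither step to compound 3 can be read. The compounds shown leave open how far allylsulfanyl truly differs from sulfanyl or hydroxy.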